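The source may hold more compounds than are shown below. What is called first, only, known or untested is meant among the compounds shown, and "the series" means these compounds.

Measured so far:
compound 1, `Nc1ccc(C(=O)O)cc1-c1nc2ccccc2n(Cc2ccccc2)c1=O`; in an assay on cells for activation of Cystic fibrosis transmembrane conductance regulator (Homo sapiens), read by fluorescence, with a stated time of 10 min (on this read-out higher numbers stand for an effect only at larger amounts of compound and lower numbers for an effect already at smaller amounts), compound 1 reaches only the assay limit, > 10000 nM.
compound 2, `O=c1[nH]c2ccccc2nc1-c1cccc([N+](=O)[O-])c1`; in this assay compound 2 likewise reaches only the assay limit, > 10000 nM.

Compound 2 therefore stands at the limit of > 10000 nM in this assay, at which 2 of the 2 values shown sit, and no number is known for it. For the measured compounds named here, both measured values are limits, so no measured step exists in this set, and nothing here separates one compound from the other.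

Compound 3, `O=c1c(-c2cccc([N+](=O)[O-])c2)nc2ccccc2n1Cc1ccco1`, differs from compound 2 by (furan-2-yl)methyl in place of hydrogen on an aromatic nitrogen. Compound 1 carries a benzyl on the corresponding nitrogen of the shared core and still sits at the limit, so the substitution of that nitrogen is not seen to bring activity into range. For compound 3 no step beyond the scatter is expected, a step that the limit leaves unreadable from compound 2 to compound 3, and the assay is expected most likely to report a limit again. The estimate for compound 3 is 20000 nM, with a range from 5000 nM to 100000 nM.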

Compound 3, half-maximal effective concentration: 20 nM
Compound 3: the middle estimate sits 1000-fold (3.00 log units) above what was measured; the measured number lies below the stated range.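

In this assay, the aromatic nitrogen opposite the ring nitrogen is a position where substitution can bring a measured number into range: (furan-2-yl)methyl in place of hydrogen gives an at least 500-fold lower number from compound 2 to compound 3 (2.69 log units; beyond the scatter). For the compounds shown here, this is the first readable step, and it starts from a limit, not from a number: the limit of > 10000 nM in this assay, at which 2 of the 3 values shown sit. Compound 1 also carries a substituent on that nitrogen, a benzyl, but it differs from compound 3 in more than one place, so the pair does not isolate the effect of the (furan-2-yl)methyl group.

Still open, going by these compounds, is whether the gain needs this particular group or would also come with a plain methyl or a benzyl on the otherwise unchanged structure of compound 3. Also open, on these data alone, is whether the nitro group of compound 3 is needed, which an amine or a nitrile in its place would test.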